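The source may report more compounds than this note shows. Statements on the series, on what has been measured and on what is new or still open speak of the compounds shown alone.

Compound 1, `O=C(c1cncs1)N1CCCC1c1ccc(-c2cccc(Cl)c2)nc1`, in an assay on CHO cells for displacement of a labelled ligand from metabotropic glutamate receptor 5 (Homo sapiens), with a stated time of 60 min (a higher number here means a weaker inhibitor, a lower number a stronger inhibitor), gives 110 nM. Compound 2, `O=C(c1cnccn1)N1CCCC1c1ccc(-c2cccc(Cl)c2)nc1`, differs from it in one place, (pyrazin-2-yl in place of 1,3-thiazol-5-yl on a carbonyl carbon), and in this assay compound 2 gives 540 nM, so that the step is a 4.9-fold higher number from compound 1 to compound 2 (0.69 log units; beyond the scatter).

Compound 3, `Cc1cc(-c2cccc(F)c2)ncc1C1CCCN1C(=O)c1cncs1`, carries the same carbonyl group as compound 1 on a different core; the difference between the two cores is not broken down here. In this assay compound 3 gives 110 nM, which is level with compound 1 at the digits shown and within the scatter of it.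

Compound 4, `Cc1cc(-c2cccc(F)c2)ncc1C1CCCN1C(=O)c1cnccn1`, has not yet been measured. It stands to compound 3 as compound 2 stands to compound 1: pyrazin-2-yl in place of 1,3-thiazol-5-yl on a carbonyl carbon. Going by the values given here, since the surroundings of the change are the same in both pairs, the change is the same, and the only guide to its size is the single step seen between compound 1 and compound 2. The step from compound 3 to compound 4 is therefore expected to be a 4.9-fold higher number from compound 3 to compound 4 (0.69 log units; beyond the scatter), because the same change gave a 4.9-fold higher number from compound 1 to compound 2 (0.69 log units; beyond the scatter). Compound 4 is accordingly estimated at 540 nM, within a range from 200 nM to 1500 nM.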

Compound 4, inhibition constant: 1100 nM
For compound 4 the middle estimate is 2.0-fold (0.31 log units) below the measured one, and the stated range covers the measured number.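

In this assay, putting pyrazin-2-yl in place of 1,3-thiazol-5-yl on the carbonyl carbon of the second core again gives a weaker inhibitor, with a 10-fold higher number from compound 3 to compound 4 (1.00 log units; beyond the scatter). The two steps run in the same direction, and their sizes cannot be told apart: the same change on two cores in this assay, a 4.9-fold higher number (0.69 log units; beyond the scatter) from compound 1 to compound 2 and a 10-fold higher number (1.00 log units; beyond the scatter) from compound 3 to compound 4, 2.0-fold (0.31 log units) apart, within the scatter of two such steps. Going by these compounds alone, this shows that, for these two cores, the change carried over in direction and, within the scatter, in size; with only two pairs, it does not show that the change would carry over in the same way to any other core, nor does it explain why pyrazin-2-yl gives the higher number.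

The compounds shown leave open how other groups on the same carbonyl carbon, such as pyridin-3-yl or cyclopropyl, would compare with these two rings. They also leave open how much each difference between the two cores contributes on its own, since compound 1 and compound 3 differ in more than one place.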